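The compounds below may be only part of what the source reports. "The series", "measured", "known", "first", "only" and "open" are said of these compounds alone.

Compound 1 `CCC(CC)(c1ccc(OCC(=O)C(C)(C)C)c(C)c1)c1ccc(C(=O)NCC(=O)OC)n1C`: in an assay on HL-60 cells for agonist activity at vitamin D3 receptor (Homo sapiens), with a stated time of 96 h (a higher number here means that more compound is needed for the effect, a lower number that less compound is needed), compound 1 gives 23 nM.
Compound 2 `CCC(CC)(c1ccc(OCC(=O)C(C)(C)C)c(C)c1)c1ccc(C(=O)NCCC(=O)OC)n1C`: in this assay compound 2 gives 790 nM.
Compound 3 `CCC(CC)(c1ccc(OCC(=O)C(C)(C)C)c(C)c1)c1ccc(C(=O)N[C@@H](C)C(=O)O)n1C`: in this assay compound 3 gives 2630 nM.

Compound 3 stands highest of the three, as a 110-fold higher number from compound 1 to compound 3 (2.06 log units; beyond the scatter) and a 3.3-fold higher number from compound 2 to compound 3 (0.52 log units; beyond the scatter) show. Compound 4 `CCC(CC)(c1ccc(OCC(=O)C(C)(C)C)c(C)c1)c1ccc(C(=O)N[C@@H](CC(=O)O)C(=O)O)n1C` differs from it by carboxy in place of hydrogen on a saturated chain carbon, two bonds along the chain from an amide-type nitrogen and a carbonyl carbon. Among the measured compounds shown here, no measured step adds a carboxy group; the steps bearing on it are a 110-fold higher number from compound 1 to compound 3 (2.06 log units; beyond the scatter) and a 3.3-fold higher number from compound 2 to compound 3 (0.52 log units; beyond the scatter), both large or modest rises on moving from ester to acid, and a 34-fold higher number from compound 1 to compound 2 (1.54 log units; beyond the scatter), a large rise on lengthening the chain. A further rise is therefore expected, of about a 2.3-fold higher number from compound 3 to compound 4 (0.36 log units; beyond the scatter). Compound 4 is estimated at 6000 nM, within 1500 nM to 25000 nM.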

Compound 4, half-maximal effective concentration: 410 nM
The estimate for compound 4 lay 15-fold (1.17 log units) above the measured number; the measured number lies below the stated range.
By their numbers in this assay, from the lowest: compound 1; then compounds 4 and 2 (each within the scatter of the next); then compound 3.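

In this assay, carboxy in place of hydrogen on this saturated chain carbon lowers the number (a 6.4-fold lower number from compound 3 to compound 4 (0.81 log units; beyond the scatter)), so adding a second carboxy group here reverses the direction of the earlier rises. The number still stays well short of the ester compound 1 (an 18-fold higher number from compound 1 to compound 4 (1.25 log units; beyond the scatter)), and the difference from compound 2 lies within the scatter (a 1.9-fold lower number from compound 2 to compound 4 (0.28 log units; within the scatter)). Nothing given here explains the drop. Going by these compounds, whether a methyl ester, a primary amide or a longer chain ending in carboxy at this carbon would do the same remains open.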